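Fluorine on the urea phenyl of a quinazoline-linked urea

This account rests on a few compounds, and the source may have more. Where it says the series, first, only, none or still open, it means among the compounds named here.

Measured compounds:
compound 1 `O=C(Nc1cccc(CNc2ncnc3ccccc23)c1)Nc1ccccc1F` — 26100 nM
compound 2 `COc1cc2ncnc(NCc3cccc(NC(=O)Nc4ccccc4)c3)c2cc1OC` — 17100 nM

Of the compounds shown here, two have been measured in a functional assay on A549 cells (Homo sapiens) for antiproliferative activity, read by MTT assay; a lower number here means a stronger inhibitor, a higher number a weaker inhibitor. Compound 1 gives 26100 nM in this assay. Compound 2 gives 17100 nM in this assay, the lower of the two numbers, though compound 1 stands within the scatter of it, so the two values cannot be set in order. Among the compounds with values here, compound 1 and compound 2 differ in more than one place, and no single step between them has been worked out; their two values simply show that both are weak inhibitors in this assay.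

The unmeasured compound 3 `COc1cc2ncnc(NCc3cccc(NC(=O)Nc4ccccc4F)c3)c2cc1OC` is built on the core of compound 2 and differs from it in one place (fluoro in place of hydrogen on an aromatic carbon). The same change, in the opposite direction, is one of the two differences between compound 1 and compound 2, but on its own it has not been measured anywhere here. With nothing in the measured pairs to point one way or the other, the step of a 1.1-fold higher number from compound 2 to compound 3 (0.02 log units; within the scatter) is expected to stay within the scatter. Compound 3 is therefore estimated at 18000 nM in this assay, with a range from 8000 nM to 40000 nM.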

Compound 3, half-maximal inhibitory concentration: 23800 nM
Beside the measured number, compound 3's estimate is 1.3-fold (0.12 log units) below it, and the stated range covers the measured number.
By their numbers in this assay, from the lowest: compounds 2, 3 and 1 (each within the scatter of the next).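

Within the data shown here, putting fluoro in place of hydrogen on an aromatic carbon of the urea's phenyl ring, on the core of compound 2, gives a 1.4-fold higher number from compound 2 to compound 3 (0.14 log units; within the scatter) in this assay and thus the first reading of this change alone. That step cannot be told apart from no change at all, so at this position, where the phenyl becomes 2-fluorophenyl, a single fluorine neither clearly strengthens nor clearly weakens a compound that is already a weak inhibitor in this assay. No supporting measurement is available to explain this reading.

The compounds shown leave open whether the same step would read alike on the core of compound 1, since a single pair on one core cannot show how far the reading carries to another. They also leave open whether this position can move the value at all, which a chloro, a methyl, a methoxy or an amine on the same carbon, or a fluoro on another carbon of that ring, could begin to show.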